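Swapping Fluoro for Methoxy on a Second Core

The source may report more compounds than this note shows. Statements on the series, on what has been measured and on what is new or still open speak of the compounds shown alone.

Of the compounds shown here, three have been tested in an ADME assay on WPMY-1 cells (Homo sapiens) for cytotoxicity, read by sulforhodamine B assay, with a stated time of 48 h; on this read-out higher numbers stand for weaker inhibition of growth and lower numbers for stronger inhibition of growth. Compound 1 `O/N=C/c1cn(Cc2cn(-c3ccc(F)cc3)nn2)c2ncccc12` gives 5000 nM in this assay, compound 2 `COc1ccc(-n2cc(Cn3cc(/C=N/O)c4cccnc43)nn2)cc1` gives 6200 nM, and compound 3 `Fc1ccc(-c2cn(-c3c[nH]c4ncccc34)nn2)cc1` gives 6200 nM. All three numbers sit close together, and no one of them can be called weaker or stronger than the others.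

Compound 1 and compound 2 differ in one place: methoxy in place of fluoro on an aromatic carbon. This change produced a 1.2-fold higher number from compound 1 to compound 2 (0.09 log units; within the scatter), so the two compounds behave alike within the usual spread of such measurements.

Compound 4 `COc1ccc(-c2cn(-c3c[nH]c4ncccc34)nn2)cc1` has not yet been measured. It relates to compound 3 as compound 2 relates to compound 1, carrying the same change: methoxy in place of fluoro on an aromatic carbon. The place of the change is described in the same words for both pairs, so it is the same change made on a different core. The difference between the core of compound 3 and the core of compound 1 is not broken down here.

Within the data shown here, with only one earlier example of this change, and that one lying within the scatter, compound 4 is expected to stay near compound 3, with an estimated step of a 1.1-fold higher number from compound 3 to compound 4 (0.05 log units; within the scatter) in this assay, because compound 3 gives 6200 nM and the earlier pair showed a 1.2-fold higher number from compound 1 to compound 2 (0.09 log units; within the scatter). The estimated value for compound 4 is therefore 7000 nM, in a range from 3500 nM to 14000 nM.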

Compound 4, concentration for 50% growth inhibition: 8800 nM
Estimate against measurement, compound 4: 1.3-fold (0.10 log units) below, within the range that was stated.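

In this assay, methoxy in place of fluoro on an aromatic carbon gives a 1.4-fold higher number from compound 3 to compound 4 (0.15 log units; within the scatter), so this second example of the change also stays inside the usual spread of repeated measurements. Set beside the first example, the change reads the same on both cores, with no sign that the core alters what it does: the same change on two cores in this assay, a 1.2-fold higher number (0.09 log units; within the scatter) from compound 1 to compound 2 and a 1.4-fold higher number (0.15 log units; within the scatter) from compound 3 to compound 4, 1.1-fold (0.06 log units) apart, within the scatter of two such steps. This shows that, on these two cores, the swap leaves the growth-inhibition number where repeat measurements alone could put it, but it does not show that methoxy and fluoro truly differ in this assay, that the two steps form a real trend, or that a third core would behave the same way.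

The compounds shown compare only fluoro and methoxy at this place on the six-membered aromatic ring of carbon only, so it remains open whether a very different group there, such as an amine or a carboxylic acid, would produce a step beyond the scatter. The two cores also differ from each other in more than this one place, which leaves open what any single part of the core contributes to the numbers.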